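This account rests on a few compounds, and the source may have more. Where it says the series, first, only, none or still open, it means among the compounds named here.

The measured compounds:
Compound 1 `CN(C)c1nc2cc(Cl)c(Cl)cc2n1COC(CO)CO`. In a functional assay on KB cells (Homo sapiens) for inhibition (a lower number here means a stronger inhibitor, a higher number a weaker inhibitor), compound 1 gives > 100000 nM, which is a limit of the assay.
Compound 2 `CN(C)c1nc2c(Cl)cc(Cl)cc2n1COC(CO)CO`. In this assay compound 2 gives > 100000 nM, likewise a limit.
Compound 3 `CNc1nc2c(Cl)c(Cl)ccc2n1COC(CO)CO`. In this assay compound 3 gives > 100000 nM, again a limit.

Compound 3 therefore stands where every value sits, at the limit of > 100000 nM in this assay, at which 3 of the 3 values shown sit; no number sets it apart from compound 1 or compound 2. Compound 4 `OCC(CO)OCn1cnc2c(Cl)c(Cl)ccc21` differs from compound 3 by hydrogen in place of methylamino on an aromatic carbon. Going by the values given here, no step between two measured compounds is known. From compound 3 to compound 4 the expected step is a number no higher from compound 3 to compound 4 (the limit leaves the size open), none beyond the scatter. Compound 4 is estimated at 100000 nM, between 30000 nM and 300000 nM, most probably reported as a limit once more.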

Compound 4, half-maximal inhibitory concentration: > 100000 nM
Compound 4: a limit, no number (the forecaster's own chance of this, stated with the estimate: 80%); the middle value lies on the limit itself.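

Compound 3 and compound 4 both give only a limit, so no step between them can be read in this assay: the limit of > 100000 nM in this assay, at which 4 of the 4 values shown sit.

The compounds shown leave open whether methylamino or hydrogen on that aromatic carbon makes any difference in this assay.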